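Replacing methoxymethyl with fluoro on compound 1

This account rests on a few compounds, and the source may have more. Where it says the series, first, only, none or still open, it means among the compounds named here.

Measured so far in a physicochemical assay for lipophilicity, at pH 7.4; a lower number here means a more polar compound, a higher number a more lipophilic compound:
compound 1 `COCc1ccccc1C1Cc2nccn2C1` gives 1.8
compound 2 `c1ccc(C2CCc3nc[nH]c3C2)cc1` gives 2.6

Compound 1 holds the lower of the two values, and compound 2 stands above it by more than the usual scatter. These two compounds differ in more than one place, so the gap between them cannot be read as the size of any single change. The next compound to be measured is compound 3 `Fc1ccccc1C1Cc2nccn2C1`, which carries fluoro in place of methoxymethyl on an aromatic carbon, ortho to a group of 8 heavy atoms (fluoro in place of methoxymethyl on an aromatic carbon). Within the data shown here, no measured pair covers this change, so no step can be carried over, and the expectation rests on the structural change alone, starting from compound 1 at 1.8. A modest upward step in this assay is expected, slightly beyond the scatter, though a step within the scatter cannot be excluded. The expected move is a number 0.40 log units higher from compound 1 to compound 3 (beyond the scatter). The estimate for compound 3 is 2.2, with an expected range from 1.8 to 2.6.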

Compound 3, distribution coefficient: 2
For compound 3 the middle estimate is 0.20 log units above the measured one; the measured number falls inside the stated range.
By their numbers in this assay, from the lowest: compounds 1 and 3 (each within the scatter of the next); then compound 2.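

In this assay, among these compounds, fluoro in place of methoxymethyl on an aromatic carbon, ortho to a group of 8 heavy atoms, gives a number 0.20 log units higher from compound 1 to compound 3 (within the scatter); this is the first step that can be read for a change in one place. At this position, methoxymethyl, with 3 heavy atoms and 1 hydrogen-bond acceptor, and fluoro, with 1 heavy atom and 0 hydrogen-bond acceptors, give values that this read-out does not separate, so compound 1 and compound 3 stand level within the scatter. No supporting measurement is available to account for the size of this step.

On these data alone, one step on one aromatic carbon cannot show whether this position tolerates substitution in general, and whether an amine, a carboxylic acid or a longer chain such as methoxyethyl there would also stay within the scatter of compound 1 remains open. Also open, as far as these compounds go, is whether fluoro on another carbon of the six-membered aromatic ring would give a step of similar size in this assay.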